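A few compounds are considered here, and "the series" means these few. Any claim that something is new, unique, unknown or untested is made for them only; others in the source may bear on it.

- compound 1 `CCCCCCCCCCCCS(=O)(=O)/C=C/c1ccc(O)c(O)c1`: 8500 nM
- compound 2 `O=S(=O)(/C=C/c1ccc(O)c(O)c1)CCC1CCCCC1`: 9800 nM

In a functional assay, read by fluorescence and spectrophotometry, with a stated time of 1 h (a lower number here means that less compound is needed, a higher number that more compound is needed for the effect), compound 2 gives 9800 nM. That places it level with compound 1 at 8500 nM, since the two values lie within the usual scatter of each other. Their tails differ, yet the numbers do not separate them. Among the compounds with values here, neither compound carries a hydroxyl group, so no measurement yet shows what one does here.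

Compound 3 `O=S(=O)(/C=C/c1ccc(O)c(O)c1)CCCCCCCCO` has 6-hydroxyhexyl in place of cyclohexyl on a saturated chain carbon, two bonds along the chain from a sulfonyl sulfur. Within the data shown here, with no measured pair to guide it, this expectation is loose: a modest move toward needing more compound, though one that could stay within the scatter. The expected change is a 1.5-fold higher number from compound 2 to compound 3 (0.18 log units; within the scatter). For compound 3 the estimated value is 15000 nM, with an expected range from 6000 nM to 40000 nM.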

Compound 3, half-maximal effective concentration: 6700 nM
The estimate for compound 3 lay 2.2-fold (0.35 log units) above the measured number, and the stated range covers the measured number.
By their numbers in this assay, from the lowest: compounds 3, 1 and 2 (each within the scatter of the next).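

In this assay, the step from a ring to an open chain carrying a hydroxyl group stays within the scatter: 6-hydroxyhexyl in place of cyclohexyl gives a change (a 1.5-fold lower number from compound 2 to compound 3 (0.17 log units; within the scatter)). Hydroxy in place of butyl on a saturated chain carbon, eight bonds along the chain from a sulfonyl sulfur, also stays within the scatter (a 1.3-fold lower number from compound 1 to compound 3 (0.10 log units; within the scatter)), so this assay does not separate the hydroxyl-bearing tail from either tail without one. Nothing here gives a reason for this result.

All three tails tested so far give numbers within the scatter of one another, and the shared core stays the same throughout. Still open, on these data alone, is whether a tail carrying an amine or a carboxylic acid, or a much shorter alkyl chain such as methyl, would move the number beyond the scatter.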